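The source may hold more compounds than are shown below. What is called first, only, known or untested is meant among the compounds shown, and "the series" means these compounds.

In a functional assay on cells (Platelet, Homo sapiens) for inhibition (a higher number here means a weaker inhibitor, a lower number a stronger inhibitor), compound 1 `CCOC(=O)c1ccc(-c2nn(C)c3ccccc23)cc1` gives 270 nM, compound 2 `CCOC(=O)c1ccc(-c2nn(Cc3cccc(Cl)c3)c3ccccc23)cc1` gives 80 nM and compound 3 `CCOC(=O)c1ccc(-c2nn(Cc3ccc(Cl)cc3)c3ccccc23)cc1` gives 120 nM. Compound 3 therefore sits within the scatter of compound 2, as a 1.5-fold higher number from compound 2 to compound 3 (0.18 log units; within the scatter) shows, and clearly under compound 1, as a 2.3-fold lower number from compound 1 to compound 3 (0.35 log units; beyond the scatter) shows. Compound 4 `CCOC(=O)c1ccc(-c2nn(Cc3cccc(F)c3)c3ccccc23)cc1` has 3-fluorophenyl in place of 4-chlorophenyl on a saturated chain carbon bound to an aromatic nitrogen. Among the measured compounds shown here, no fluorine-bearing compound has been measured yet, so the closest guide is the exchange of 3-chlorophenyl for 4-chlorophenyl, a 1.5-fold higher number from compound 2 to compound 3 (0.18 log units; within the scatter) already noted. Placing a chlorophenyl on this carbon had a modest effect, seen in a 3.4-fold lower number from compound 1 to compound 2 (0.53 log units; beyond the scatter) and a 2.3-fold lower number from compound 1 to compound 3 (0.35 log units; beyond the scatter). Neither step suggests a large change in this assay, so no shift beyond the scatter is expected. The expected change is a 1.2-fold lower number from compound 3 to compound 4 (0.08 log units; within the scatter). For compound 4 the estimated value is 100 nM, with an expected range from 50 nM to 200 nM.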

Compound 4, half-maximal inhibitory concentration: 270 nM
Estimate against measurement, compound 4: 2.7-fold (0.43 log units) below; the measured number lies above the stated range.
By their numbers in this assay, from the lowest: compounds 2 and 3 (each within the scatter of the next); then compounds 1 and 4 (each within the scatter of the next).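

In this assay, the halogen on this benzyl group proves to matter, which the two chlorophenyl compounds, within the scatter of each other, could not show: 3-fluorophenyl in place of 4-chlorophenyl gives a 2.3-fold higher number from compound 3 to compound 4 (0.35 log units; beyond the scatter), and fluoro in place of chloro on an aromatic carbon gives a 3.4-fold higher number from compound 2 to compound 4 (0.53 log units; beyond the scatter). The gain that each chlorophenyl group brought over the hydrogen of compound 1 is absent with 3-fluorophenyl, as no change at the digits printed from compound 1 to compound 4 (within the scatter) shows, so an aromatic ring on this carbon is not enough by itself. No available evidence explains why chloro and fluoro differ here.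

The compounds shown leave open whether a bromo or a trifluoromethyl group on this ring would track chloro or fluoro. They also leave open how an unsubstituted phenyl on this carbon would compare.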